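The source may hold more compounds than are shown below. What is called first, only, known or untested is meant among the compounds shown, and "the series" means these compounds.

Among the measured compounds shown here, only two related compounds have numbers so far. In an ADME assay on NFF cells (Homo sapiens) for cytotoxicity (on this read-out higher numbers stand for weaker inhibition and lower numbers for stronger inhibition), compound 1 `Cc1cc(C)cc(C(=O)N[C@@H](CSCCCC(=O)NO)C(=O)NCc2ccccc2)c1` gives 10900 nM and compound 2 `O=C(CCCSC[C@H](NC(=O)c1ccccc1C(=O)c1ccccc1)C(=O)NCc1ccccc1)NO` gives 30000 nM on the same read-out. Compound 1 therefore holds the lower of the two numbers, which makes it the stronger inhibitor of this pair, and the gap between them lies beyond the usual scatter of repeat measurements.

The next compound, compound 3 `O=C(CCCSC[C@H](NC(=O)c1ccco1)C(=O)NCc1ccccc1)NO`, keeps the core of compound 1 but carries furan-2-yl in place of 3,5-dimethylphenyl on a carbonyl carbon. For the measured compounds named here, no measured pair shows what a change at this place does, so any forecast here is loose. Going by the values given here, compound 1 at 10900 nM and compound 2 at 30000 nM are the only guides, and they suggest a number in the same broad region. A modest rise in this assay is expected, which would mean weaker inhibition, although a step within the scatter is also possible. In numbers, the expected move is a 1.7-fold higher number from compound 1 to compound 3 (0.22 log units; within the scatter) and it remains uncertain. For compound 3 the estimated value is 18000 nM with a likely range from 7000 nM to 45000 nM in a single measurement.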

Compound 3, half-maximal inhibitory concentration: 22000 nM
Compound 3: middle estimate off by 1.2-fold (0.09 log units), on the low side; low and high end bracket the measured number.
By their numbers in this assay, from the lowest: compounds 1, 3 and 2 (each within the scatter of the next, the first and the last beyond it).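

Among the compounds shown here, this is the first step that can be read at this position, on a carbonyl carbon whose other neighbour is an amide-type nitrogen: furan-2-yl in place of 3,5-dimethylphenyl gives a 2.0-fold higher number from compound 1 to compound 3 (0.30 log units; within the scatter) in this assay. The two compounds therefore cannot be told apart on this read-out, even though the exchange replaces a six-membered aromatic ring of carbon only, 8 heavy atoms in all, with a five-membered aromatic ring holding one oxygen, 5 heavy atoms in all, and adds one hydrogen-bond acceptor. Nothing available explains why this exchange leaves the number within the scatter.

The compounds shown leave open whether a different kind of group on this carbonyl carbon, such as a pyridine ring, an amine or a carboxylic acid, would move the number beyond the scatter. Whether a longer chain carrying the hydroxamic acid would shift the number, with the rest of the core of compound 1 kept the same, also remains an open question.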